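From bromo to trifluoromethyl on the shared core

The source may report more compounds than this note shows. Statements on the series, on what has been measured and on what is new or still open speak of the compounds shown alone.

Compounds measured in an ADME assay on microsomes from liver (Homo sapiens) for metabolic stability, read by LC-MS; a higher number here means faster removal of the compound, a lower number slower removal:
Compound 1 `FC(F)(F)c1cccc(N[C@H]2CC[C@@H](Nc3ccnc(C(F)(F)F)n3)CC2)c1`: 7.5 mL.min-1.g-1
Compound 2 `FC(F)(F)c1nccc(N[C@H]2CC[C@@H](Nc3ccc4ncc(Cl)n4n3)CC2)n1`: 9.9 mL.min-1.g-1
Compound 3 `FC(F)(F)c1nccc(N[C@H]2CC[C@@H](Nc3ccc4nnc(Br)n4n3)CC2)n1`: < 3 mL.min-1.g-1 (a limit)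

Compound 3 stands at the limit of < 3 mL.min-1.g-1 in this assay, at which 1 of the 3 values shown sits, so its reading is a limit and not a number. Compound 4 `FC(F)(F)c1nccc(N[C@H]2CC[C@@H](Nc3ccc4nnc(C(F)(F)F)n4n3)CC2)n1` carries trifluoromethyl in place of bromo on an aromatic carbon of a five-membered aromatic ring with 3 nitrogen (trifluoromethyl in place of bromo on an aromatic carbon). For the measured compounds named here, no measured pair isolates this change, so the expectation rests on compound 3 and its limit of < 3 mL.min-1.g-1 alone. The expected step of an at least 1.1-fold higher number from compound 3 to compound 4 (0.06 log units; that floor lies within the scatter) is small, upward if anything, and not beyond the scatter. For compound 4 the estimated value in this assay is 3.5 mL.min-1.g-1, with an expected range from 1.5 mL.min-1.g-1 to 8 mL.min-1.g-1.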

Compound 4, intrinsic clearance in microsomes: < 3 mL.min-1.g-1
Compound 4 was reported as a limit; the forecaster's own chance of this, stated with the estimate: 50%; at least 1.1-fold (0.06 log units) between middle value and limit.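

For the compounds shown here, compound 3 and compound 4 are both reported as limits, so no step between them can be read: the limit of < 3 mL.min-1.g-1 in this assay, at which 2 of the 4 values shown sit. The compounds shown leave open whether trifluoromethyl and bromo at this place differ at all in this assay.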